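Replacing the 3-bromophenyl group of compound 2

The compounds below may be only part of what the source reports. "The series", "measured", "known", "first", "only" and "open" are said of these compounds alone.

- compound 1 `CCCCCc1c(C)nc2nc(SCc3ccc(Cl)cc3)nn2c1Nc1cc(-c2ccccc2)[nH]n1`: 6390 nM
- compound 2 `Cc1cc(Nc2cc(-c3ccccc3)[nH]n2)n2nc(SCc3cccc(Br)c3)nc2n1`: 5140 nM
- compound 3 `Cc1cc(Nc2cc(C(C)(C)C)[nH]n2)n2nc(SCc3ccc(Br)cc3)nc2n1`: 7290 nM

All three values come from a functional assay on MCF7 cells (Homo sapiens) for inhibition, read by MTT assay, with a stated time of 72 h (on this read-out higher numbers stand for weaker inhibition and lower numbers for stronger inhibition), and lie close together. Compound 2 stands within the usual scatter of both compound 1 and compound 3, so these numbers do not rank the three compounds. For the measured compounds named here, no two of them differ in only one place, so no measured step is available as a guide.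

Compound 4 `Cc1cc(Nc2cc(-c3ccccc3)[nH]n2)n2nc(SCc3nc4ccccc4[nH]3)nc2n1` carries 1H-benzimidazol-2-yl in place of 3-bromophenyl on a saturated chain carbon bound to a sulfur. Going by the values given here, none of the measured compounds has this group, so the data give no direction for the change. Compound 2 at 5140 nM is therefore the starting point, and no step beyond the scatter is expected in this assay in either direction. The estimated change is a 1.3-fold higher number from compound 2 to compound 4 (0.10 log units; within the scatter) and it is expected to stay small. In this assay compound 4 is expected at 6500 nM with an estimated range from 2000 nM to 20000 nM given the lack of any close comparison.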

Compound 4, half-maximal inhibitory concentration: 2730 nM
For compound 4 the middle estimate is 2.4-fold (0.38 log units) above the measured one, within the range that was stated.
By their numbers in this assay, from the lowest: compounds 4, 2, 1 and 3 (each within the scatter of the next, the first and the last beyond it).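

In this assay, the place on a saturated chain carbon bound to a sulfur takes 1H-benzimidazol-2-yl instead of 3-bromophenyl with a step of a 1.9-fold lower number from compound 2 to compound 4 (0.27 log units; within the scatter) and no change beyond the usual scatter. For the compounds shown here, this is the first comparison of compounds that differ in only one place, and it shows that this position can hold a group with a second ring, a hydrogen-bond donor and a hydrogen-bond acceptor, and without the bromine, while the reading stays in the same range. Nothing measured here explains why the two groups read alike.

As far as these compounds go, whether an amine, a carboxylic acid or a longer alkyl chain at this place would also read alike remains open. From the compounds shown here alone, it is also open whether the same exchange would give a similar step on the core of compound 3.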